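The compounds below may be only part of what the source reports. "The series", "measured", "known", "first", "only" and "open" are said of these compounds alone.

Measured in a functional assay on CCRF-CEM cells (Homo sapiens) for antiproliferative activity, with a stated time of 72 h; a higher number here means a weaker inhibitor, a lower number a stronger inhibitor:
- Compound 1 `OC[C@H]1O[C@@H](n2cnc3c(NCc4ccccc4F)ncnc32)[C@H](O)[C@@H]1O`: 4600 nM
- Compound 2 `COc1ccccc1CNc1ncnc2c1ncn2[C@@H]1O[C@H](CO)[C@@H](O)[C@H]1O`: 3200 nM

With only these two numbers to compare, compound 2 at 3200 nM lies within the scatter of compound 1, so the two cannot be ranked. The unmeasured compound 3 `OC[C@H]1O[C@@H](n2cnc3c(NCc4ccc(Cl)cc4Cl)ncnc32)[C@H](O)[C@@H]1O` keeps the shared core and differs from compound 2 in one place: 2,4-dichlorophenyl in place of 2-methoxyphenyl on a saturated chain carbon bound to a nitrogen on an aromatic ring. Put simply, 2,4-dichlorophenyl takes the place of 2-methoxyphenyl on a saturated chain carbon bound to a nitrogen on an aromatic ring.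

Among the measured compounds shown here, only one measured step bears on this change: a 1.4-fold lower number from compound 1 to compound 2 (0.16 log units; within the scatter). That step swapped fluoro for methoxy on an aromatic carbon of the same part of the molecule, and it stayed small. For the measured compounds named here, no compound carrying chlorine has been measured yet, so the data give no direction for this swap. The expected step in this assay is a 1.1-fold lower number from compound 2 to compound 3 (0.03 log units; within the scatter), which means none beyond the scatter in either direction. The range is kept wide, since a single small step is thin evidence. For compound 3 the estimated value is 3000 nM, with an expected range from 1000 nM to 9000 nM.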

Compound 3, half-maximal inhibitory concentration: 86700 nM
Estimate against measurement, compound 3: 29-fold (1.46 log units) below, outside the stated range (above it).
By their numbers in this assay, from the lowest: compounds 2 and 1 (each within the scatter of the next); then compound 3.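

Replacing 2-methoxyphenyl with 2,4-dichlorophenyl in this assay brings a large loss of activity (a 27-fold higher number from compound 2 to compound 3 (1.43 log units; beyond the scatter)), and replacing 2-fluorophenyl with the same group brings a similar one (a 19-fold higher number from compound 1 to compound 3 (1.28 log units; beyond the scatter)). The earlier swap of fluoro for methoxy could suggest that this place, on a saturated chain carbon bound to a nitrogen on an aromatic ring, hardly reacts to a change, but the new compound shows that it can: compound 1 and compound 2 stay within the scatter of each other, and compound 3 alone stands apart. No measurement shown here explains why this change weakens the compound so much.

A compound carrying 2-chlorophenyl or 4-chlorophenyl in this place would show whether one chlorine alone is enough for the loss or whether it takes both together. Also open, going by these compounds, is how this place would respond to an amine on the ring, or to a longer chain between the nitrogen and the ring, such as phenethyl in place of benzyl.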